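One Fluorine Less: Expected Cytotoxicity of Compound 4

The source may report more compounds than this note shows. Statements on the series, on what has been measured and on what is new or still open speak of the compounds shown alone.

Three related compounds have been tested in an ADME assay on cells (Macrophage, Mus musculus) for cytotoxicity, read by resazurin assay, with a stated time of 3 days; a lower number here means a stronger inhibitor, a higher number a weaker inhibitor. Compound 1 `O=C(Nc1cccc(C(F)(F)F)c1)c1cc(Cl)ccc1O` gives 5900 nM, compound 2 `O=C(Nc1ccc(F)c(C(F)(F)F)c1)c1cc(Cl)ccc1O` gives 5300 nM, and compound 3 `O=C(Nc1cc(C(F)(F)F)ccc1F)c1cc(F)ccc1O` gives 5100 nM. The change from compound 2 to compound 1 is hydrogen in place of fluoro on an aromatic carbon, and it produced a 1.1-fold higher number from compound 2 to compound 1 (0.05 log units; within the scatter). The cores of compound 2 and compound 3 differ, and that difference is not broken down here; their two numbers lie close together.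

Compound 4 `O=C(Nc1cccc(C(F)(F)F)c1)c1cc(F)ccc1O` has not been measured. It differs from compound 3 by hydrogen in place of fluoro on an aromatic carbon. Within the data shown here, this is the same kind of change as the one from compound 2 to compound 1, though the surroundings are not identical: in compound 1 the position is ortho to a trifluoromethyl group and para to a large group, whereas in compound 4 it is ortho to a large group and para to a trifluoromethyl group. Since the earlier step stayed within the scatter, compound 4 is expected to show a step of a 1.1-fold higher number from compound 3 to compound 4 (0.04 log units; within the scatter), resting on how small the earlier 1.1-fold higher number from compound 2 to compound 1 (0.05 log units; within the scatter) was. Compound 4 is estimated at 5600 nM in this assay, with a range from 3200 nM to 9800 nM.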

Compound 4, half-maximal inhibitory concentration: 6100 nM
Beside the measured number, compound 4's estimate is 1.1-fold (0.04 log units) below it; the range from low to high includes it.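

Replacing fluoro with hydrogen on an aromatic carbon carried over from one core to the other without a visible difference in this assay: the same change on two cores in this assay, a 1.1-fold higher number (0.05 log units; within the scatter) from compound 2 to compound 1 and a 1.2-fold higher number (0.08 log units; within the scatter) from compound 3 to compound 4, 1.1-fold (0.03 log units) apart, within the scatter of two such steps

The new step, a 1.2-fold higher number from compound 3 to compound 4 (0.08 log units; within the scatter), is small, and so is the swap on the other ring, a 1.0-fold higher number from compound 1 to compound 4 (0.01 log units; within the scatter), so neither change moves the number within these compounds. Among these compounds, this shows only that a change with no measurable effect on one core also had none on a second; it does not show that a change with a real effect would carry over in the same way.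

The compounds shown carry only hydrogen, fluoro or chloro at the changed positions and keep trifluoromethyl throughout. As far as these compounds go, it stays open how the number would respond to a different kind of group, such as an amine or a carboxylic acid on either ring, or a methyl in place of trifluoromethyl.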